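Cyclooctyl for Cyclohexyl on the Amide Nitrogen

The source may report more compounds than this note shows. Statements on the series, on what has been measured and on what is new or still open speak of the compounds shown alone.

Compound 1, `CC(C)(C)C(=O)N(CCCCCCN1C[C@H](O)[C@@H](O)[C@H](O)[C@H]1CO)C1CCCCC1`, is tested in an ADME assay on BHK cells (Mesocricetus auratus) for cytotoxicity, read by MTT assay; on this read-out higher numbers stand for lower toxicity in this test and lower numbers for higher toxicity in this test. In this assay compound 1 gives only a limit, > 500000 nM. Compound 2, `CC(C)(C)C(=O)N(CCCCCCN1C[C@H](O)[C@@H](O)[C@H](O)[C@H]1CO)C1CC1`, carries a cyclopropyl group on the amide-type nitrogen instead. In this assay compound 2 likewise reaches only a limit, > 500000 nM. Compound 3, `CC(C)(C)C(=O)N(CCCCCCN1C[C@H](O)[C@@H](O)[C@H](O)[C@H]1CO)C1CCCCCC1`, carries a cycloheptyl group there. In this assay compound 3 again yields only a limit, > 500000 nM. The steps a step that the two limits leave unreadable from compound 1 to compound 2, a step that the two limits leave unreadable from compound 1 to compound 3 and a step that the two limits leave unreadable from compound 2 to compound 3 therefore have no readable size, as the limit of > 500000 nM in this assay, at which 3 of the 3 values shown sit, shows. Compound 4, `CC(C)(C)C(=O)N(CCCCCCN1C[C@H](O)[C@@H](O)[C@H](O)[C@H]1CO)C1CCCCCCC1`, differs from compound 1 in one place: cyclooctyl in place of cyclohexyl on an amide-type nitrogen. Because all three measured analogues sit at the limit of > 500000 nM in this assay, at which 3 of the 3 values shown sit, compound 4 is expected to behave the same, with a step that the limit leaves unreadable from compound 1 to compound 4 expected to stay within the scatter. The estimate for compound 4 is 600000 nM, between 250000 nM and 1500000 nM.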

Compound 4, half-maximal cytotoxic concentration: 208000 nM
The estimate for compound 4 lay 2.9-fold (0.46 log units) above the measured number, outside the stated range (below it).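

In this assay, going by these compounds alone, cyclooctyl is the only one of the four rings on this amide-type nitrogen that gives a real number rather than a limit, and that number signals higher toxicity in this test: an at least 2.4-fold lower number from compound 1 to compound 4 (0.38 log units; beyond the scatter), an at least 2.4-fold lower number from compound 3 to compound 4 (0.38 log units; beyond the scatter) and an at least 2.4-fold lower number from compound 2 to compound 4 (0.38 log units; beyond the scatter). The steps among compounds 1, 2 and 3 cannot be read, so they show no gradual trend with ring size: the limit of > 500000 nM in this assay, at which 3 of the 4 values shown sit.

From the compounds shown here alone, it remains open whether this toxicity depends on ring size or simply on the number of carbons. An open octyl chain or a phenyl ring at the same nitrogen could help separate the two.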